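Methyl in Place of Trifluoromethyl: Compound 2 to Compound 4

The source may report more compounds than this note shows. Statements on the series, on what has been measured and on what is new or still open speak of the compounds shown alone.

Measured compounds:
compound 1, `CCCCCCCCCCCCCCCCNCn1nc(-c2ccc3c(c2)OCCO3)oc1=S`, in a functional assay, with a stated time of 6 min; on this read-out higher numbers stand for weaker inhibition and lower numbers for stronger inhibition: 22900 nM
compound 2, `FC(F)(F)c1ccccc1NCn1nc(-c2ccc3c(c2)OCCO3)oc1=S`, in this assay: 9220 nM
compound 3, `FC(F)(F)c1cc(NCn2nc(-c3ccc4c(c3)OCCO4)oc2=S)cc(C(F)(F)F)c1`, in this assay: 9320 nM

All three compounds share one core and differ only in the group carried on the nitrogen outside it. On the numbers in hand, compound 2 holds the lowest value of the three in this assay. Compound 3 sits at practically the same number, a gap that lies within the usual scatter, so no order between compound 2 and compound 3 can be read from these data. Compound 1 gives a higher number than compound 2, and that gap lies beyond the scatter.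

The next compound, compound 4, `Cc1ccccc1NCn1nc(-c2ccc3c(c2)OCCO3)oc1=S`, departs from compound 2 by a single change, (methyl in place of trifluoromethyl on an aromatic carbon). Among the compounds with values here, no pair of measured compounds shows what this exchange does in this assay, so there is no measured step to lean on. Both measured compounds carrying a group of the trifluoromethyl kind, compound 2 and compound 3, come out close to one another, which gives no sign of the exchange being large. The step from compound 2 to compound 4 is therefore expected to be small, a 1.3-fold higher number from compound 2 to compound 4 (0.11 log units; within the scatter), and possibly to stay within the scatter. Compound 4 is estimated at 12000 nM, with a range from 4000 nM to 36000 nM.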

Compound 4, half-maximal inhibitory concentration: 3450 nM
The estimate for compound 4 lay 3.5-fold (0.54 log units) above the measured number; measured number below the stated range.
By their numbers in this assay, from the lowest: compound 4; then compounds 2 and 3 (each within the scatter of the next); then compound 1.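

In this assay, the exchange of trifluoromethyl for methyl on this aromatic carbon, ortho to a large group, gives a 2.7-fold lower number from compound 2 to compound 4 (0.43 log units; beyond the scatter). Within the data shown here, this is the first single-place change, and it shows that the group at this position can shift the read-out by a modest step beyond the scatter, towards stronger inhibition, as the four heavy atoms of trifluoromethyl give way to the one heavy atom of methyl. No measurement shown here accounts for the step, so the result stands as an observation on this one pair of compounds.

The compounds shown leave open how other groups on this same carbon would behave, for example a chlorine atom, a methoxy group, an amine or a longer chain such as ethyl, and so whether the step from trifluoromethyl to methyl belongs to a wider trend or stands alone. They also leave open whether the same exchange would give a step of similar size on the aromatic ring of compound 3, which carries two trifluoromethyl groups.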